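Indol-5-yl amine variant of the methoxy analogue

A few compounds are considered here, and "the series" means these few. Any claim that something is new, unique, unknown or untested is made for them only; others in the source may bear on it.

Compound 1 `O=C(/C=C\Nc1ccc(F)cc1)c1nc(-c2ccc(C(F)(F)F)cc2)n2ccccc12` reaches only the limit > 30000 nM in a functional assay on HCT-116 cells (Homo sapiens) for cytotoxicity, read by MTT assay, with a stated time of 48 h; a lower number here means a stronger inhibitor, a higher number a weaker inhibitor.
Compound 2 `O=C(/C=C\Nc1cnc2ccccc2c1)c1nc(-c2ccc(C(F)(F)F)cc2)n2ccccc12` reaches only the limit > 30000 nM in this assay.
Compound 3 `COc1ccc(-c2nc(C(=O)/C=C\Nc3ccc(F)cc3)c3ccccn23)cc1` reaches only the limit > 30000 nM in this assay.

Compound 3 thus stands where every measured member of the series stands, at the limit of > 30000 nM in this assay, at which 3 of the 3 values shown sit; no number separates it from compound 1 or compound 2. The two measured steps, a step that the two limits leave unreadable from compound 1 to compound 2 and a step that the two limits leave unreadable from compound 1 to compound 3, are both unreadable, since each joins two limits.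

Compound 4 `COc1ccc(-c2nc(C(=O)/C=C\Nc3ccc4[nH]ccc4c3)c3ccccn23)cc1` differs from compound 3 by 1H-indol-5-yl in place of 4-fluorophenyl on an amine nitrogen. The step from compound 1 to compound 2 also exchanges the group on the amine nitrogen, so it is the one that bears on this change, but its size cannot be read. With no readable step in the series, no shift beyond the scatter is expected for a number no higher from compound 3 to compound 4 (the limit leaves the size open), and compound 4 is expected to remain at the limit in this assay. The estimate for compound 4 is 30000 nM, within 10000 nM to 100000 nM.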

Compound 4, half-maximal inhibitory concentration: 17400 nM
The estimate for compound 4 lay 1.7-fold (0.24 log units) above the measured number; the measured number falls inside the stated range.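

In this assay, as far as these compounds go, the exchange of 4-fluorophenyl for 1H-indol-5-yl on the amine nitrogen gives an at least 1.7-fold lower number from compound 3 to compound 4 (0.23 log units; that floor lies within the scatter), so the true size of the step stays open and it cannot be called a shift beyond the scatter. The earlier steps shown here cannot be read, as each joins two limits. Compound 4 is thus the only compound shown with a number rather than a limit, which shows that a value can be read at this position on the methoxy compound: the limit of > 30000 nM in this assay, at which 3 of the 4 values shown sit.

Still open, from the compounds shown here alone, is whether the same exchange on compound 1, with its trifluoromethyl group, would also give a number. Also open, going by these compounds, is whether the indole hydrogen-bond donor counts or only the added ring, a question that a 1-methyl-1H-indol-5-yl group on the amine nitrogen would address.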